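A few compounds are considered here, and "the series" means these few. Any claim that something is new, unique, unknown or untested is made for them only; others in the source may bear on it.

Compound 3 `CC(=O)NC[C@H]1CN(c2ccc(OC[C@H](O)CNc3ccncc3)c(F)c2)C(=O)O1` gives 0.02 in a physicochemical assay for lipophilicity, read by HPLC; on this read-out higher numbers stand for higher lipophilicity and lower numbers for lower lipophilicity. Its companions compound 1 `CC(=O)NC[C@H]1CN(c2ccc(OC[C@H](O)CNc3cccnc3)c(F)c2)C(=O)O1` with -0.18 and compound 2 `CC(=O)NC[C@H]1CN(c2ccc(OC[C@@H](O)CNc3ccncc3)c(F)c2)C(=O)O1` with -0.04 lie within the scatter of it: a number 0.20 log units higher from compound 1 to compound 3 (within the scatter), a number 0.14 log units higher from compound 1 to compound 2 (within the scatter), and a number 0.06 log units higher from compound 2 to compound 3 (within the scatter), the last pair standing apart only through (the fact that compounds 2 and 3 differ only in the configuration as drawn). The step to compound 4 `CC(=O)NC[C@H]1CN(c2ccc(OC[C@@H](O)CNC3CC3)c(F)c2)C(=O)O1` brings (2-(cyclopropylamino)-1-hydroxyethyl in place of 1-hydroxy-2-((pyridin-4-yl)amino)ethyl on a saturated chain carbon bound to an oxygen on an aromatic ring). Going by the values given here, none of the measured steps touches this change; they concern the pyridinyl position and the configuration at the chain carbon, and all stayed within the scatter. For compound 4 the number is therefore estimated with little support, as -0.4 in this assay, the expected range running from -1.1 to 0.3. The expected step is a number 0.42 log units lower from compound 3 to compound 4 (beyond the scatter).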

Compound 4, partition coefficient: 0.02
For compound 4 the middle estimate is 0.42 log units below the measured one; low and high end bracket the measured number.
By their numbers in this assay, from the lowest: compounds 1, 2, 3 and 4 (each within the scatter of the next).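

Cyclopropyl in place of pyridin-4-yl on an amine nitrogen leaves this assay within the scatter (a number 0.06 log units higher from compound 2 to compound 4 (within the scatter)). The replacement of the whole side chain reads the same way (no change at the digits printed from compound 3 to compound 4 (within the scatter)) and (a number 0.20 log units higher from compound 1 to compound 4 (within the scatter)), so at this position the read-out does not separate the three-membered carbon ring from either pyridinyl group. Nothing measured here gives a cause for this. Open, going by these compounds, is whether a morpholine, a carboxylic acid or a longer alkyl chain on that amine nitrogen would also stay within the scatter.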